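This account rests on a few compounds, and the source may have more. Where it says the series, first, only, none or still open, it means among the compounds named here.

Compound 1 `COc1ncnc2c1c(-c1cccs1)cn2[C@@H]1O[C@H](CO)[C@@H](O)[C@H]1O` gives 80 nM in a functional assay on HCT-116 cells (Homo sapiens), read by MTT assay, with a stated time of 72 h; on this read-out higher numbers stand for weaker inhibition and lower numbers for stronger inhibition.
Compound 2 `COc1ncnc2c1c(-c1ccccc1)cn2[C@@H]1O[C@H](CO)[C@@H](O)[C@H]1O` reaches only a limit of this assay, > 20000 nM.

Compound 1 therefore stands alone on the numbers: it carries the only number shown, while the one other value is a limit, (the limit of > 20000 nM in this assay, at which 1 of the 2 values shown sits). Within the data shown here, the single measured step, an at least 250-fold higher number from compound 1 to compound 2 (2.39 log units; beyond the scatter), changes the five-membered ring hanging from the shared core and leaves untouched the group that compound 3 alters.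

Compound 3 `CN(C)c1ncnc2c1c(-c1cccs1)cn2[C@@H]1O[C@H](CO)[C@@H](O)[C@H]1O` differs from compound 1 in one place. dimethylamino in place of methoxy on an aromatic carbon No measured step touches this position, so nothing shown bears on it directly; the only comparison available is that compound 1 holds a number while compound 2 sits at a limit. Among the measured compounds shown here, with no comparable step to lean on, the expectation is for a change in this assay no larger than the usual scatter, in either direction. The estimate for compound 3 is 150 nM, with a range from 40 nM to 600 nM. The expected step is a 1.9-fold higher number from compound 1 to compound 3 (0.27 log units; within the scatter), staying within the scatter.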

Compound 3, half-maximal inhibitory concentration: > 20000 nM
Compound 3 gave a limit, no number; the forecaster's own chance of this, stated with the estimate: 10%; middle value at least 130-fold (2.12 log units) away from the limit.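

Replacing methoxy with dimethylamino on this aromatic carbon of the shared core, with the thiophen-2-yl group kept in place, gives an at least 250-fold higher number from compound 1 to compound 3 (2.39 log units; beyond the scatter) in this assay. The earlier step had shown a large dependence only on the group carried by the five-membered ring, whereas this one shows that the methoxy position is also far from indifferent to change, even though the replacement is small and the acceptor count under the two groups is the same. Each of the two single changes away from compound 1 ends at a limit and not a number, so the full size of neither step can be read: the limit of > 20000 nM in this assay, at which 2 of the 3 values shown sit.

The compounds shown leave open whether the loss belongs to dimethylamino in particular or to any replacement of methoxy on this carbon, a question that a methylamino group, a primary amine or a plain methyl group there would address. They also leave open how far this position tolerates anything larger or smaller than methoxy, such as an ethoxy group or a single hydrogen.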